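A Carboxy-to-Fluoro Step Without a Measured Precedent

The source may report more compounds than this note shows. Statements on the series, on what has been measured and on what is new or still open speak of the compounds shown alone.

Compound 1 `CCOC(=O)C1=CNC2=C(/C=N/c3ccccc3C(=O)O)CCC(C)N2C1=O`: in a functional assay on the whole organism with Rattus norvegicus as the target (on this read-out lower numbers stand for an effect already at smaller amounts and higher numbers for an effect only at larger amounts of compound), compound 1 gives 24.8 umol/kg.
Compound 2 `CC1CCC(/C=N/c2ccccc2C(=O)O)=C2NC=C(C(=O)O)C(=O)N21`: in this assay compound 2 gives 1.11 umol/kg.

Among the compounds with values here, of the two numbers so far, compound 2 holds the lower one, and compound 1 is its only neighbour. Within the data shown here, the single measured step, a 22-fold lower number from compound 1 to compound 2 (1.35 log units; beyond the scatter), came from hydrogen in place of ethyl on an oxygen next to a carbonyl group, a change on the shared core and not on the aromatic ring.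

Compound 3 `CC1CCC(/C=N/c2ccccc2F)=C2NC=C(C(=O)O)C(=O)N21` differs from compound 2 by fluoro in place of carboxy on an aromatic carbon. Among the measured compounds shown here, no measured step bears on this change: the one step that exists concerns the ester and acid on the core of compound 1 and says nothing about the carboxy on the aromatic ring. The expectation therefore rests on the bare fact that a carboxy is lost and a fluoro enters, with no number behind it. Compound 3 is expected to give a somewhat higher number than compound 2, a 3.2-fold higher number from compound 2 to compound 3 (0.50 log units; beyond the scatter), though this is a guess rather than an inference. The estimate for compound 3 in this assay is 3.5 umol/kg, within a range from 0.8 umol/kg to 15 umol/kg.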

Compound 3, dose for 50% inhibition: 14.5 umol/kg
The estimate for compound 3 lay 4.1-fold (0.62 log units) below the measured number; the range from low to high includes it.
By their numbers in this assay, from the lowest: compound 2; then compounds 3 and 1 (each within the scatter of the next).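

Within the data shown here, the aromatic carboxy was the same in the earlier compounds, so this is the first sign that the number in this assay depends on this position, which is ortho to a large group. Fluoro in place of carboxy on an aromatic carbon brings a 13-fold higher number from compound 2 to compound 3 (1.12 log units; beyond the scatter), a large step on the ring and not on the shared core. Read beside a 22-fold lower number from compound 1 to compound 2 (1.35 log units; beyond the scatter), it shows that compound 2 loses its low number in both of the single changes shown, one at the carboxylic acid on the core and one at the carboxy on the aromatic ring, while nothing measured here offers a reason for the size of either step.

The compounds shown leave open whether a hydroxyl, an amine or a methyl ester on the same aromatic carbon would give a number like that of compound 2 or one like that of compound 3. They also leave open how the two changes combine, as in a compound that carries an ethyl ester on the core together with fluoro on the aromatic ring.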